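Chalcone-pyrazole series: dimethoxyphenyl for dichlorophenyl on the ketone

The compounds below may be only part of what the source reports. "The series", "measured", "known", "first", "only" and "open" are said of these compounds alone.

Compound 1 `COc1cc(-c2cc(/C=C/C(=O)c3ccc(Cl)c(Cl)c3)[nH]n2)cc(OC)c1OC` gives 5% in a functional assay on NCI-H322M cells (Homo sapiens) for cytotoxicity, read by sulforhodamine B assay, with a stated time of 48 h, tested at 100 uM (on this read-out lower numbers stand for a stronger effect and higher numbers for a weaker effect at the one concentration tested), the highest of the three numbers recorded; compound 2 `COc1ccc(-c2cc(/C=C/C(=O)c3ccc(N)cc3)[nH]n2)cc1OC` gives -88% and compound 3 `COc1ccc(-c2cc(/C=C/C(=O)c3ccc(N)cc3)[nH]n2)cc1` gives -98%, both far below compound 1 and beyond the scatter from it. Among the measured compounds shown here, the only single-point step recorded, a number 10 percentage points lower from compound 2 to compound 3 (within the scatter), lies within the scatter and concerns a methoxy on the other aromatic ring, so it does not bear on the change considered here.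

Compound 4 `COc1ccc(C(=O)/C=C/c2cc(-c3cc(OC)c(OC)c(OC)c3)n[nH]2)cc1OC` differs from compound 1 by 3,4-dimethoxyphenyl in place of 3,4-dichlorophenyl on a carbonyl carbon. For the measured compounds named here, no measured pair isolates this exchange on the carbonyl carbon: compounds 2 and 3 carry a different group there and also differ from compound 1 on the far ring, so their strongly negative numbers cannot be transferred to compound 4 directly. Any expectation therefore carries wide uncertainty. Given that compound 1 alone stands near zero and the two other members of the series lie deeply negative, compound 4 is estimated at -40%, within -95% to 15%, an expected step of a number 45 percentage points lower from compound 1 to compound 4 (beyond the scatter).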

Compound 4, a percentage reported as activity, at one concentration (the size of the read-out at that concentration, not a potency): -90%
For compound 4 the middle estimate is 50 percentage points above the measured one; the range from low to high includes it.
By their numbers in this assay, from the lowest: compounds 3, 4 and 2 (each within the scatter of the next); then compound 1.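

In this assay, among the compounds shown here, 3,4-dimethoxyphenyl in place of 3,4-dichlorophenyl on a carbonyl carbon gives a number 95 percentage points lower from compound 1 to compound 4 (beyond the scatter), the first step that isolates this position. The rest of the structure is held constant across this pair, so the exchange alone accounts for the whole step and the value of compound 1 depends strongly on the group at this position. No available evidence gives a reason for the size of this step.

Still open, from the compounds shown here alone, is whether the step follows the departure of the chlorines or the entry of the methoxy groups, and whether both methoxy groups are needed. An unsubstituted phenyl on the carbonyl carbon of the core of compound 1 would help separate these readings.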